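Pyridine-linked triaryl series: methylfuran to chlorophenyl swap

The source may report more compounds than this note shows. Statements on the series, on what has been measured and on what is new or still open speak of the compounds shown alone.

Of the compounds shown here, two have numbers so far. Compound 1 `Clc1ccc(-c2cc(-c3ccc(Cl)o3)cc(-c3cccs3)n2)cc1` gives 20900 nM in a functional assay on K562 cells (Homo sapiens) for cytotoxicity, in the presence of a further agent that is not named here; on this read-out higher numbers stand for weaker inhibition and lower numbers for stronger inhibition. Compound 2 `Cc1ccc(-c2cc(-c3ccc(Cl)o3)cc(-c3ccsc3)n2)o1` gives 23300 nM in this assay, a number that sits together with that of compound 1 within the usual scatter, so neither can be placed above the other. Compound 3 `Clc1cccc(-c2cc(-c3ccc(Cl)o3)cc(-c3ccsc3)n2)c1` differs from compound 2 by 3-chlorophenyl in place of 5-methylfuran-2-yl on an aromatic carbon. Among the compounds with values here, no measured pair shows what such a change does here, so the step from compound 2 to compound 3 is expected to be small in this assay, likely inside the scatter, at a 1.3-fold lower number from compound 2 to compound 3 (0.11 log units; within the scatter). Compound 3 is thus estimated at 18000 nM, within 7000 nM to 50000 nM.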

Compound 3, half-maximal inhibitory concentration: 23000 nM
The estimate for compound 3 lay 1.3-fold (0.11 log units) below the measured number; the measured number falls inside the stated range.
By their numbers in this assay, from the lowest: compounds 1, 3 and 2 (each within the scatter of the next).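

In this assay, 3-chlorophenyl in place of 5-methylfuran-2-yl on the aromatic carbon next to the ring nitrogen gives a 1.0-fold lower number from compound 2 to compound 3 (0.01 log units; within the scatter). This first measured pair for the change does not tell the two groups apart, although one is a five-membered aromatic ring with a hetero atom and the other a six-membered aromatic ring of carbon only. Nothing on hand gives a reason for this result.

As far as these compounds go, whether this position would respond to an amine or a carboxylic acid remains open. From the compounds shown here alone, the contributions of the thiophen-3-yl and 5-chlorofuran-2-yl groups also remain open.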